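Moving from 2-chlorophenyl to 4-chlorophenyl: a small expected step

A few compounds are considered here, and "the series" means these few. Any claim that something is new, unique, unknown or untested is made for them only; others in the source may bear on it.

Measured so far in a functional assay on HL-60 cells (Homo sapiens) for antiproliferative activity, read by MTT assay, with a stated time of 72 h; on this read-out lower numbers stand for stronger inhibition and higher numbers for weaker inhibition:
Compound 1 `CC(C)(C)c1ccc(OCCCON2C(N)=NC(N)=NC23CCSCC3)cc1`: 280 nM
Compound 2 `NC1=NC2(CCSCC2)N(OCCCOc2cccc(Cl)c2Cl)C(N)=N1`: 30 nM
Compound 3 `NC1=NC2(CCSCC2)N(OCCCOc2ccccc2Cl)C(N)=N1`: 390 nM

Compound 3 gives 390 nM and cannot be told apart from compound 1 on these numbers, while compound 2 lies clearly lower. Compound 4 `NC1=NC2(CCSCC2)N(OCCCOc2ccc(Cl)cc2)C(N)=N1` has the same atoms as compound 3 joined differently: 4-chlorophenyl in place of 2-chlorophenyl on an oxygen on a saturated carbon and so carries 4-chlorophenyl in place of 2-chlorophenyl on an oxygen on a saturated carbon.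

Within the data shown here, one measured step bears on this change. It is a 13-fold higher number from compound 2 to compound 3 (1.11 log units; beyond the scatter) and it is large, so a single chloro can count heavily in this assay in that pair. Among the measured compounds shown here, that step removes a chloro rather than moving one, and no measured compound carries the 4-chlorophenyl group, so the data fix neither size nor direction firmly.

A modest shift towards lower numbers is expected, with the expected step being a 1.8-fold lower number from compound 3 to compound 4 (0.25 log units; within the scatter) and staying within the scatter. For compound 4 the estimated value is 220 nM with 70 nM and 650 nM as the ends of the expected range.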

Compound 4, half-maximal inhibitory concentration: 430 nM
The estimate for compound 4 lay 2.0-fold (0.29 log units) below the measured number; the measured number falls inside the stated range.
By their numbers in this assay, from the lowest: compound 2; then compounds 1, 3 and 4 (each within the scatter of the next).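

In this assay, 4-chlorophenyl in place of 2-chlorophenyl on an oxygen on a saturated carbon gives a 1.1-fold higher number from compound 3 to compound 4 (0.04 log units; within the scatter), so moving this single chloro makes no readable difference on these numbers. Compound 2, with its 2,3-dichlorophenyl group, stands apart, with a 14-fold higher number from compound 2 to compound 4 (1.16 log units; beyond the scatter) matching the earlier 13-fold higher number from compound 2 to compound 3 (1.11 log units; beyond the scatter), whereas chloro in place of tert-butyl gives a 1.5-fold higher number from compound 1 to compound 4 (0.19 log units; within the scatter), which also stays within the scatter. Nothing shown gives a measured reason for these results.

Going by these compounds, it remains open whether a 3-chlorophenyl group alone would match compound 2 or whether both chloro groups are needed. On these data alone, the reading of a 2,4-dichlorophenyl or 3,4-dichlorophenyl group, or of a methoxy or nitrile on the same ring, also remains open.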